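Swapping a methylphenyl for a hydroxyphenyl on a kinase binder

This account rests on a few compounds, and the source may have more. Where it says the series, first, only, none or still open, it means among the compounds named here.

Three compounds share one core and differ only in the aryl group attached to it. In an assay for binding affinity to dual specificity mitogen-activated protein kinase kinase 4 (Homo sapiens), read by KINOMEscan, tested at 100 nM (on this read-out higher numbers stand for a weaker effect at the one concentration tested and lower numbers for a stronger effect), compound 1 `CCCS(=O)(=O)Nc1ccc(F)c(C(=O)c2n[nH]c3ncc(-c4ccccc4F)cc23)c1F` gives 2%, compound 2 `CCCS(=O)(=O)Nc1ccc(F)c(C(=O)c2n[nH]c3ncc(-c4ccccc4C)cc23)c1F` gives 7%, and compound 3 `CCCS(=O)(=O)Nc1ccc(F)c(C(=O)c2n[nH]c3ncc(-c4cccc(C)c4)cc23)c1F` gives 15%. Compound 3 thus stands highest of the three numbers; its gap to compound 2 lies within the scatter, while its gap to compound 1 lies beyond it.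

Compound 4 `CCCS(=O)(=O)Nc1ccc(F)c(C(=O)c2n[nH]c3ncc(-c4ccccc4O)cc23)c1F` has not yet been measured. It differs from compound 3 in one place: 2-hydroxyphenyl in place of 3-methylphenyl on an aromatic carbon.

Going by the values given here, two measured steps bear on this. a number 13 percentage points higher from compound 1 to compound 3 (beyond the scatter), and a number 8 percentage points higher from compound 2 to compound 3 (within the scatter). Both steps replaced an aryl with a group in the 2-fluorophenyl or 2-methylphenyl pattern by 3-methylphenyl and both moved the number upward, one beyond the scatter. Compound 4 returns to the 2-substituted pattern, so a move back downward in this assay is expected, roughly undoing the first of those steps: a number 9 percentage points lower from compound 3 to compound 4 (within the scatter) is the expected step. Among the compounds with values here, no measured compound carries a hydroxyl, so its own contribution is unknown. For compound 4 the estimate is 6%, with a range from 1% to 20%.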

Compound 4, a percentage reported as activity, at one concentration (the size of the read-out at that concentration, not a potency): 9%
Compound 4: the middle estimate sits 3 percentage points below what was measured; the measured number falls inside the stated range.
By their numbers in this assay, from the lowest: compounds 1, 2, 4 and 3 (each within the scatter of the next, the first and the last beyond it).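

In this assay, the 2-hydroxyphenyl group gives a number 6 percentage points lower from compound 3 to compound 4 (within the scatter), and the comparisons with the two other compounds carrying a group in this 2-substituted pattern give a number 2 percentage points higher from compound 2 to compound 4 (within the scatter) and a number 7 percentage points higher from compound 1 to compound 4 (within the scatter). This aromatic carbon on the shared core can therefore carry a hydroxy group, and with it the hydrogen-bond donor and acceptor that 3-methylphenyl lacks, without a step beyond the scatter from any of the three earlier compounds, even though compound 1 and compound 3 are themselves separated by more than the scatter. Nothing at hand explains how the hydroxy group acts here, so its role at this position remains unassigned.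

These compounds do not show whether the result is specific to a hydroxy group or would extend to an amine or a carboxylic acid on the same aryl ring, or to a longer chain such as ethoxy. Each number is also the size of the read-out at one concentration rather than a potency, so small differences in true affinity among these compounds remain unresolved.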